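Compound 4: removing the chain from the aromatic nitrogen

This account rests on a few compounds, and the source may have more. Where it says the series, first, only, none or still open, it means among the compounds named here.

Within the data shown here, in a functional assay on A-375 cells (Homo sapiens) for cytotoxicity, read by MTT assay, with a stated time of 72 h (on this read-out lower numbers stand for stronger inhibition and higher numbers for weaker inhibition), compound 1 `O=C1c2c[n+]([O-])c3ccccc3c2C(=O)c2c1c1ccccc1n2CCN1CCCC1` gives 430 nM, the lowest of the three numbers so far. Compound 3 `CCCN1CCN(CCCCn2c3c(c4ccccc42)C(=O)c2c[n+]([O-])c4ccccc4c2C3=O)CC1` gives 870 nM, and compound 2 `CCCCN1CCN(CCCCn2c3c(c4ccccc42)C(=O)c2c[n+]([O-])c4ccccc4c2C3=O)CC1` gives 2150 nM.

The next comparison is with compound 4 `O=C1c2c[n+]([O-])c3ccccc3c2C(=O)c2[nH]c3ccccc3c21`. The change is hydrogen in place of 2-(pyrrolidin-1-yl)ethyl on an aromatic nitrogen.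

Among the measured compounds shown here, three measured steps bear on this position, all of them through changes in the chain. They are a 2.0-fold higher number from compound 1 to compound 3 (0.31 log units; beyond the scatter), a 5.0-fold higher number from compound 1 to compound 2 (0.70 log units; beyond the scatter) and a 2.5-fold lower number from compound 2 to compound 3 (0.39 log units; beyond the scatter). Each is modest but beyond the scatter. For the measured compounds named here, both steps away from compound 1 raise the number, yet neither removes the chain, and no measured compound has hydrogen at this position. The guidance is therefore indirect, and the uncertainty is wide.

A modest move to a higher number in this assay is expected, of roughly the size of the steps already seen. The estimated step is a 2.3-fold higher number from compound 1 to compound 4 (0.37 log units; beyond the scatter). For compound 4 the expected value is 1000 nM, with an estimated range from 250 nM to 4000 nM.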

Compound 4, half-maximal inhibitory concentration: 660 nM
For compound 4 the middle estimate is 1.5-fold (0.18 log units) above the measured one; measured number inside the range.
By their numbers in this assay, from the lowest: compounds 1, 4 and 3 (each within the scatter of the next, the first and the last beyond it); then compound 2.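

In this assay, among these compounds, the only step that removes the chain altogether is a 1.5-fold higher number from compound 1 to compound 4 (0.19 log units; within the scatter) and so leaves hydrogen and 2-(pyrrolidin-1-yl)ethyl on the aromatic nitrogen indistinguishable on this read-out. The earlier steps only exchanged one chain for another, and a 5.0-fold higher number from compound 1 to compound 2 (0.70 log units; beyond the scatter) and a 2.0-fold higher number from compound 1 to compound 3 (0.31 log units; beyond the scatter) were both beyond the scatter, which left open whether any chain at this position was needed; for the cytotoxicity seen here, the 2-(pyrrolidin-1-yl)ethyl chain of compound 1 is now shown not to be required, as the unsubstituted compound 4 stands within the scatter of it. No measurement available here accounts for this result.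

Still open, from the compounds shown here alone, is whether a small group such as methyl, or a chain ending in a primary amine or a carboxylic acid, on this aromatic nitrogen would stay within the scatter of compound 4. Also unresolved is how much of the steps to compound 2 and compound 3 belongs to the piperazine ring and how much to the longer chain, since both change together in those compounds.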